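Removing the Bromine: From Compound 2 to Compound 3

The source may hold more compounds than are shown below. What is called first, only, known or untested is meant among the compounds shown, and "the series" means these compounds.

The shared core of these compounds is seen in compound 1 `CCCn1c(=O)[nH]c2nc(-c3ccc(S(=O)(=O)N4CCN(c5cccc(Cl)c5)CC4)cc3)[nH]c2c1=O`, which carries a chloro group. In an assay on CHO cells for displacement of a labelled ligand from adenosine receptor A3 (Homo sapiens), read by scintillation counting, with a stated time of 45 min, in the presence of a further agent that is not named here (on this read-out higher numbers stand for weaker inhibition and lower numbers for stronger inhibition), compound 1 gives 53.5 nM. Compound 2 `CCCn1c(=O)[nH]c2nc(-c3ccc(S(=O)(=O)N4CCN(c5cccc(Br)c5)CC4)cc3)[nH]c2c1=O` differs only in having bromo in place of chloro on an aromatic carbon. In this assay compound 2 gives > 1000 nM, which is a limit of the assay rather than a number. The step of an at least 18-fold higher number from compound 1 to compound 2 (1.27 log units; beyond the scatter) thus shows a large loss of binding, and since the reading for compound 2 sits at the limit of > 1000 nM in this assay, at which 1 of the 2 values shown sits, the true size of that loss is not known. Compound 3 `CCCn1c(=O)[nH]c2nc(-c3ccc(S(=O)(=O)N4CCN(c5ccccc5)CC4)cc3)[nH]c2c1=O` takes the change one stage further: hydrogen in place of bromo on an aromatic carbon. For the measured compounds named here, no measured step removes the halogen altogether, so the only guide is that swapping chloro for bromo cost a great deal, and hydrogen is a different group again. The expected step is an at least 3.3-fold lower number from compound 2 to compound 3 (0.52 log units; beyond the scatter), a recovery into the measurable range of this assay. Compound 3 is therefore estimated to give about 300 nM, with a plausible range from 50 nM to 3000 nM.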

Compound 3, inhibition constant: > 1000 nM
Compound 3: a limit, no number (the forecaster's own chance of this, stated with the estimate: 30%); at least 3.3-fold (0.52 log units) between middle value and limit.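

In this assay compound 3 gives > 1000 nM and this is a limit of the assay, not a number. Hydrogen in place of chloro on the aromatic carbon gives an at least 18-fold higher number from compound 1 to compound 3 (1.27 log units; beyond the scatter) and so shows that the loss seen with bromo is not specific to that swap: a phenyl ring with no halogen at all also fails to keep the binding, and of the three groups shown at this place, only chloro gives a reading that is an actual number. The step from compound 2 to compound 3 cannot be read, and neither of the two can be ranked above the other, because each reading is only a limit: the limit of > 1000 nM in this assay, at which 2 of the 3 values shown sit.

As far as these compounds go, how far compound 2 and compound 3 really lie beyond that limit remains unknown, so bromo and hydrogen may be equally poor or quite different from each other. Also open, from the compounds shown here alone, is whether another group on this aromatic carbon, such as fluoro, methyl or methoxy, would keep the binding in the way chloro does or lose it in the way bromo and hydrogen do.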